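Compound 3 to compound 4: hydroxycarbamoyl end replaced

The source may report more compounds than this note shows. Statements on the series, on what has been measured and on what is new or still open speak of the compounds shown alone.

Values in a functional assay on MCF7 cells (Homo sapiens) for inhibition, read by MTT assay, with a stated time of 72 h; on this read-out higher numbers stand for weaker inhibition and lower numbers for stronger inhibition:
compound 1 `Nc1nc2cc(-c3nn(CCCC(=O)NO)c4ncnc(N)c34)ccc2o1` gives > 50000 nM (a limit of the assay)
compound 2 `Nc1nc2cc(-c3nn(CCCCC(=O)NO)c4ncnc(N)c34)ccc2o1` gives 14000 nM
compound 3 `Nc1nc2cc(-c3nn(CCCCCCCCC(=O)NO)c4ncnc(N)c34)ccc2o1` gives 42100 nM

In this assay compound 3 (42100 nM) holds the higher of the two true numbers, and the gap to its nearest neighbour is a 3.0-fold higher number from compound 2 to compound 3 (0.48 log units; beyond the scatter) within this short series. The move to compound 4 `CNC(=O)CCCCCCCn1nc(-c2ccc3oc(N)nc3c2)c2c(N)ncnc21` is methylcarbamoyl in place of (hydroxycarbamoyl)methyl on a saturated chain carbon, seven bonds along the chain from an aromatic nitrogen and can also be read as 4-(hydroxycarbamoyl)butyl to 3-(methylcarbamoyl)propyl.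

For the measured compounds named here, no measured compound carries methylcarbamoyl, so no measured step covers this exchange directly. The closest guides are the chain steps among the hydroxycarbamoyl compounds, an at least 3.5-fold lower number from compound 1 to compound 2 (0.55 log units; beyond the scatter) and a 3.0-fold higher number from compound 2 to compound 3 (0.48 log units; beyond the scatter) in size. Both are modest, and they do not run one way: compound 2 goes against any steady trend with chain length. Compound 3 already lies close to the limit reached by compound 1, which leaves little measurable room for a rise.

The expected step is a 1.3-fold higher number from compound 3 to compound 4 (0.12 log units; within the scatter) and is estimated to lean toward a higher number without clearly passing the scatter. Compound 4 is estimated at 55000 nM (range 20000 nM to 120000 nM) and may well be reported only as a limit.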

Compound 4, half-maximal inhibitory concentration: 7220 nM
Estimate against measurement, compound 4: 7.6-fold (0.88 log units) above; the whole stated range lies above it.
By their numbers in this assay, from the lowest: compounds 4 and 2 (each within the scatter of the next); then compound 3. At a limit, above all of these: compound 1.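

In this assay, the exchange of (hydroxycarbamoyl)methyl for methylcarbamoyl on a saturated chain carbon, seven bonds along the chain from an aromatic nitrogen, gives a 5.8-fold lower number from compound 3 to compound 4 (0.77 log units; beyond the scatter), so at this place a hydroxycarbamoyl end is not required for a number as low as any in the series. Set against the other measured compound with a true number, the exchange gives a 1.9-fold lower number from compound 2 to compound 4 (0.29 log units; within the scatter), so no order can be drawn between these two, and the series now holds two different chain ends with indistinguishable numbers. The step of an at least 6.9-fold lower number from compound 1 to compound 4 (0.84 log units; beyond the scatter) rests on a limit of the assay and not on a number, and its true size stays unknown: the limit of > 50000 nM in this assay, at which 1 of the 4 values shown sits.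

The exchange alters the chain as well as its end, and the compounds shown do not separate these two parts of the step. A carboxylic acid or an unsubstituted carbamoyl at the chain end, or methylcarbamoyl on a shorter or a longer chain, would show whether the lower number follows the end group or the chain.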